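Replacing a hexyl tail with an amino group

The source may hold more compounds than are shown below. What is called first, only, known or untested is meant among the compounds shown, and "the series" means these compounds.

Compound 2 `CCCCCCCCSS[C@H]1C[C@H](n2cc(C)c(=O)[nH]c2=O)O[C@@H]1CO` is one of two measured compounds. In a functional assay on MOLT-4 cells (Homo sapiens) for cytotoxicity (on this read-out higher numbers stand for weaker inhibition and lower numbers for stronger inhibition), compound 2 gives 26000 nM, the lower of the two numbers shown. Its neighbour, compound 1 `C=CCSS[C@H]1C[C@H](n2cc(C)c(=O)[nH]c2=O)O[C@@H]1CO`, gives 34000 nM in this assay, and the step of a 1.3-fold lower number from compound 1 to compound 2 (0.12 log units; within the scatter) shows that exchanging one hydrocarbon chain for a longer one moved the number little.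

Compound 3 `Cc1cn([C@H]2C[C@H](SSCCN)[C@@H](CO)O2)c(=O)[nH]c1=O` differs from compound 2 by amino in place of hexyl on a saturated chain carbon, two bonds along the chain from a sulfur. Within the data shown here, the only measured step, a 1.3-fold lower number from compound 1 to compound 2 (0.12 log units; within the scatter), swapped one hydrocarbon chain for another and stayed within the scatter; neither measured compound carries an amino group, so no step bears directly on this change. Given that small effect from compound 1 to compound 2, I expect a step of a 1.5-fold higher number from compound 2 to compound 3 (0.19 log units; within the scatter) for compound 3, with wide uncertainty. Compound 3 is therefore estimated at 40000 nM in this assay, within a range of 12000 nM to 150000 nM.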

Compound 3, half-maximal inhibitory concentration: 163000 nM
Compound 3: the middle estimate sits 4.1-fold (0.61 log units) below what was measured; the measured number lies above the stated range.
By their numbers in this assay, from the lowest: compounds 2 and 1 (each within the scatter of the next); then compound 3.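

In this assay, the end of this chain turns out to matter: amino in place of hexyl, on a saturated chain carbon two bonds along the chain from a sulfur, gives a 6.3-fold higher number from compound 2 to compound 3 (0.80 log units; beyond the scatter), a step beyond the scatter, whereas the exchange between the two hydrocarbon chains stayed within it. The other available comparison agrees, since aminomethyl in place of vinyl gives a 4.8-fold higher number from compound 1 to compound 3 (0.68 log units; beyond the scatter), so compound 3 is weaker than both compounds with a hydrocarbon chain.

The compounds shown cannot separate the effect of the amine from that of the shorter chain, and a short hydrocarbon chain such as ethyl, a longer chain ending in an amine, or a carboxylic acid at the chain end would help to tell them apart. No measurement shown accounts for the higher number of compound 3.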